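The compounds below may be only part of what the source reports. "The series", "measured", "known", "first", "only" and "open" are said of these compounds alone.

In a functional assay on HL-60 cells (Homo sapiens) for inhibition, read by MTT assay, with a stated time of 72 h (on this read-out higher numbers stand for weaker inhibition and lower numbers for stronger inhibition), compound 1 (`Cc1nc(-c2ccccc2F)c(C(=O)N2CCN(c3cc(Cl)cc(Cl)c3)CC2)s1`) gives 157 nM and compound 3 (`Cc1nc(-c2ccccc2)c(C(=O)N2CCN(c3cccc(Cl)c3Cl)CC2)o1`) gives 133 nM as its value, and these two values lie within the usual scatter of each other. Compound 2 (`COc1ccc(-c2nc(C)oc2C(=O)N2CCN(c3cccc(Cl)c3)CC2)cc1OC`) stands apart from both. It is reported as "not active" (no number reported) and has no single number, so it cannot be placed on the numerical scale.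

The next compound to be tested is compound 4 (`CC(=O)Nc1cccc(-c2nc(C)oc2C(=O)N2CCN(c3cccc(Cl)c3)CC2)c1`), which has 3-acetamidophenyl in place of 3,4-dimethoxyphenyl on an aromatic carbon. Going by the values given here, no measured pair of compounds isolates this kind of replacement, and compound 1 and compound 3 each differ from compound 2 in more than one place. The size of the step in this assay therefore cannot be read from the data and has no numerical starting point.

The expected direction is toward stronger inhibition, perhaps enough to give a measurable number. Even so, compound 4 is not expected to reach the level of compound 3 at 133 nM as a matter of course, and it may remain without a number, as compound 2 did.

For compound 4 the estimated value is 1000 nM with an expected range from 150 nM to 7000 nM in this estimate.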

Compound 4, half-maximal inhibitory concentration: 208 nM
The estimate for compound 4 lay 4.8-fold (0.68 log units) above the measured number; measured number inside the range.
By their numbers in this assay, from the lowest: compounds 3, 1 and 4 (each within the scatter of the next).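

In this assay, going by these compounds alone, compound 4 gives 208 nM while compound 2 is reported as "not active" with no number, so no step between them can be read. The compounds shown leave open how large the change from 3,4-dimethoxyphenyl to 3-acetamidophenyl is on this read-out. No measured evidence bears on a cause for this result.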